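Working notes: 4-methylpiperazin-1-yl in place of isopropyl

This account rests on a few compounds, and the source may have more. Where it says the series, first, only, none or still open, it means among the compounds named here.

Among the compounds with values here, in a functional assay on A549 cells (Homo sapiens) for inhibition, read by MTT assay, with a stated time of 72 h (on this read-out lower numbers stand for stronger inhibition and higher numbers for weaker inhibition), compound 1 `CC(C)c1ccc(NC(=O)C2CCN(C/C=C/c3ccccc3)CC2)cc1` gives 9430 nM, the only actual number so far. Compound 2 `COc1ccccc1NC(=O)C1CCN(C/C=C/c2ccccc2)CC1` reads > 100000 nM, which is a limit of the assay and not a number.

Compound 3 `CN1CCN(c2ccc(NC(=O)C3CCN(C/C=C/c4ccccc4)CC3)cc2)CC1` keeps the core of compound 1 and changes one group: 4-methylpiperazin-1-yl in place of isopropyl on an aromatic carbon. In words, this is 4-methylpiperazin-1-yl in place of isopropyl on an aromatic carbon, para to a large group.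

Within the data shown here, only one measured step bears on this: an at least 10-fold higher number from compound 1 to compound 2 (1.02 log units; beyond the scatter), large and beyond the scatter, with 2-methoxyphenyl in place of 4-isopropylphenyl on the amide-type nitrogen. That step shows how far the number can move when the 4-isopropylphenyl group is altered, but the group that enters there is a different one, so it fixes no size for the present change. A smaller move towards a higher number is therefore expected in this assay: a 1.6-fold higher number from compound 1 to compound 3 (0.20 log units; within the scatter).

The estimate for compound 3 is 15000 nM, with an expected range from 4000 nM to 60000 nM.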

Compound 3, half-maximal inhibitory concentration: 19900 nM
The estimate for compound 3 lay 1.3-fold (0.12 log units) below the measured number; the measured number falls inside the stated range.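

In this assay, 4-methylpiperazin-1-yl in place of isopropyl on the aromatic carbon, para to a large group, is a modest loss: a 2.1-fold higher number from compound 1 to compound 3 (0.32 log units; beyond the scatter). Within the data shown here, the earlier step replaced the whole 4-isopropylphenyl group on the amide-type nitrogen, whereas this one leaves the rest of compound 1 intact and alters only the group at this place, so it is the first direct reading of this position. A much larger group, bringing a six-membered non-aromatic ring with 2 hetero atoms, is accepted here with a measurable number and without reaching the ceiling of the read-out: the limit of > 100000 nM in this assay, at which 1 of the 3 values shown sits.

From the compounds shown here alone, one replacement cannot separate the contribution of the ring from that of its nitrogen atoms, and it remains open whether a morpholine, a dimethylamino group or a carboxylic acid at the same place would stay close to compound 1 or move further from it. Also open, going by these compounds, is whether any group on this aromatic carbon can give a lower number than compound 1, which gives 9430 nM.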